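This account rests on a few compounds, and the source may have more. Where it says the series, first, only, none or still open, it means among the compounds named here.

Three related compounds have been measured in a functional assay on CHO-K1 cells with Glucose-dependent insulinotropic receptor (Homo sapiens) as the target, read by a luciferase reporter, with a stated time of 5 h; on this read-out lower numbers stand for smaller maximal responses and higher numbers for larger maximal responses. Compound 3 `COC(=O)N1CCC(Oc2ncnc3c2CCN3c2ccc(S(C)(=O)=O)cc2F)CC1` gives 119% in this assay, the highest of the three numbers. Compound 2 `CC(C)OC(=O)N1CCC(Oc2ncnc3c2CCN3c2ccc(-c3nccs3)cc2F)CC1` gives 74%, and compound 1 `CC(C)OC(=O)N1CCC(Oc2cccc3c2CCN3c2ccc(S(C)(=O)=O)cc2F)CC1` gives 62%; both stand below compound 3 by more than the scatter. Each of them differs from compound 3 in more than one place, so no single-change step can be read from them.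

Compound 4 `CCCCOC(=O)N1CCC(Oc2ncnc3c2CCN3c2ccc(S(C)(=O)=O)cc2F)CC1` has not yet been measured in this assay. It differs from compound 3 by propyl in place of hydrogen on a saturated chain carbon bound to an oxygen next to a carbonyl group. Within the data shown here, no measured step covers this change. The expectation rests on compound 1 with 62% and compound 2 with 74%, which carry a larger chain at the same place but also other changes, so a moderate drop is expected rather than a large one. The expected step is a number 24 percentage points lower from compound 3 to compound 4 (beyond the scatter). Compound 4 is estimated to reach 95% in this assay, within a range from 65% to 125%.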

Compound 4, largest response reached (reported as percent of maximum), in percent of the reference or control that the assay uses: 131%
Estimate against measurement, compound 4: 36 percentage points below; the measured number lies above the stated range.
By their numbers in this assay, from the lowest: compound 1; then compound 2; then compound 3; then compound 4.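

In this assay, among these compounds, this is the first single-change step at this position, and it runs upward: placing propyl instead of hydrogen on the saturated chain carbon bound to an oxygen next to a carbonyl group gives a number 12 percentage points higher from compound 3 to compound 4 (beyond the scatter). Going from methoxycarbonyl to butoxycarbonyl therefore costs no maximal response on this core, so the position accepts the larger chain and the response even rises modestly. Nothing measured here explains why the response rises.

As far as these compounds go, whether the response keeps climbing with a longer chain such as hexyl, or holds up with a cyclohexyl ring or an amine at this place, remains open. A single step also cannot show whether the same change would act alike on a different core.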